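Oxazolylmethoxy for ethoxy: expected permeability of compound 4

The source may hold more compounds than are shown below. What is called first, only, known or untested is meant among the compounds shown, and "the series" means these compounds.

In an ADME assay on LLC-PK1 cells (Sus scrofa) for permeability (on this read-out higher numbers stand for higher permeability and lower numbers for lower permeability), compound 1 (`COC[C@]12C[C@H]1[C@@](C)(c1cc(NC(=O)c3ccc(Cl)cn3)cc(F)c1F)N=C(N)S2`) gives 13 10^-6 cm/s, compound 2 (`C#CCOc1cnc(C(=O)Nc2cc(F)c(F)c([C@@]3(C)N=C(N)S[C@@]4(COC)C[C@H]43)c2)c(C)c1`) gives 19 10^-6 cm/s and compound 3 (`CCOc1cnc(C(=O)Nc2cc(F)c(F)c([C@@]3(C)N=C(N)S[C@@]4(COC)C[C@H]43)c2)cn1`) gives 25 10^-6 cm/s. Compound 3 therefore stands within the scatter of both other compounds. Compound 4 (`COC[C@]12C[C@H]1[C@@](C)(c1cc(NC(=O)c3cnc(OCc4ncco4)cn3)cc(F)c1F)N=C(N)S2`) carries one change from compound 3: 1,3-oxazol-2-yl in place of methyl on a saturated chain carbon bound to an oxygen on an aromatic ring. Put simply, 1,3-oxazol-2-yl replaces methyl on a saturated chain carbon bound to an oxygen on an aromatic ring.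

Three measured steps are nearest: a 1.5-fold higher number from compound 1 to compound 2 (0.16 log units; within the scatter), a 1.9-fold higher number from compound 1 to compound 3 (0.28 log units; within the scatter) and a 1.3-fold higher number from compound 2 to compound 3 (0.12 log units; within the scatter). All stay within the scatter, but none introduces this group, so the direction is poorly defined. A modest, expected a 1.5-fold lower number from compound 3 to compound 4 (0.17 log units; within the scatter) stays within the scatter. For compound 4 the estimated value is 17 10^-6 cm/s, with an expected range of 8 10^-6 cm/s to 30 10^-6 cm/s.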

Compound 4, apparent permeability: 48 10^-6 cm/s
The estimate for compound 4 lay 2.8-fold (0.45 log units) below the measured number; measured number outside the range, above it.
By their numbers in this assay, from the lowest: compounds 1, 2, 3 and 4 (each within the scatter of the next, the first and the last beyond it).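

At the saturated chain carbon bound to an oxygen on an aromatic ring, 1,3-oxazol-2-yl in place of methyl gives, in this assay, a 1.9-fold higher number from compound 3 to compound 4 (0.28 log units; within the scatter). This position therefore holds a five-membered aromatic ring with two hetero atoms, and the step stays within the scatter. Nothing measured here gives a cause for the step.

Open, going by these compounds, is how a plain phenyl ring, a longer chain such as butyl or an amine on this carbon would read in this assay. Also open, on these data alone, is whether the oxazole ring itself matters, since a phenyl ring or another ring at this carbon would be needed to tell.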